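The compounds below may be only part of what the source reports. "The series", "measured", "known", "first", "only" and "open" are said of these compounds alone.

Of the compounds shown here, three that share one core have been measured in a physicochemical assay for lipophilicity, at pH 3; on this read-out lower numbers stand for lower lipophilicity and higher numbers for higher lipophilicity. Compound 1 `Cc1cccc2c(NCc3ccco3)nc(NC(C)C)nc12` gives 1.57, compound 2 `Cc1ccc2c(NCc3ccco3)nc(NC(C)C)nc2c1` gives 1.58 and compound 3 `COc1cccc2c(NCc3ccco3)nc(NC(C)C)nc12` gives 2.99. Compound 1 and compound 2 are built from the same atoms joined differently; the difference between the two cores is not broken down here, and their two values lie within the scatter of each other. From compound 1 to compound 3 the change is methoxy in place of methyl on an aromatic carbon, and it made a number 1.42 log units higher from compound 1 to compound 3 (beyond the scatter).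

Compound 4 `COc1ccc2c(NCc3ccco3)nc(NC(C)C)nc2c1` has not been measured yet. From compound 2 to compound 4 the change is methoxy in place of methyl on an aromatic carbon, the same kind of change, though not the same: in compound 1 the place is ortho to a fused ring and meta to a fused ring, whereas in compound 2 it is meta to a fused ring and para to a fused ring. For compound 4 the expected step in this assay is a number 1.32 log units higher from compound 2 to compound 4 (beyond the scatter). That expectation rests on the step of a number 1.42 log units higher from compound 1 to compound 3 (beyond the scatter), the only measured case of this kind of change, together with the closeness of the values of compound 1 and compound 2. Compound 4 is therefore estimated at 2.9, with a likely range from 2.2 to 3.5.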

Compound 4, distribution coefficient: 3.11
Estimate against measurement, compound 4: 0.21 log units below; measured number inside the range.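

In this assay methoxy in place of methyl on an aromatic carbon gave a number 1.53 log units higher from compound 2 to compound 4 (beyond the scatter) and, in the other core, gave a number 1.42 log units higher from compound 1 to compound 3 (beyond the scatter) as the matching step. Both steps are large and run in the same direction, so in these two cores the change carried over even though the group sits at a different place on the ring in each. This rests on only two pairs of compounds, so it does not show that the step would hold in other cores or at other places, and nothing shown explains its size.

Going by these compounds, whether ethoxy, an amine or a longer chain on the same aromatic carbon would move this assay in a similar way remains open. On these data alone, the groups on the other side of the shared core are the same in all four compounds, so it is also open whether the step would survive with a carboxylic acid among them.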